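Aryl exchange from compound 3 to compound 4

This account rests on a few compounds, and the source may have more. Where it says the series, first, only, none or still open, it means among the compounds named here.

Compound 3 `COc1nc(-c2cccc(F)c2)ccc1[C@@H](c1ccccc1)[C@@](O)(CCN(C)C)c1cccc2ccccc12` gives 62.8 ug/mL in a toxicity assay on HeLa cells (Homo sapiens) for cytotoxicity (a lower number here means that less compound is tolerated, a higher number that more compound is tolerated), nominally the highest of the two numbers recorded, though its nearest neighbour, compound 1 `COc1nc(C2CCCCC2)ccc1[C@@H](c1ccccc1)[C@@](O)(CCN(C)C)c1cccc2ccccc12` at 57.7 ug/mL, sits within the scatter, as the step of a 1.1-fold higher number from compound 1 to compound 3 (0.04 log units; within the scatter) shows. Compound 2 `COc1nc(-c2ccc(Br)cc2)ccc1[C@@H](c1ccccc1)[C@@](O)(CCN(C)C)c1cccc2ccccc12` reaches only a limit of this assay, > 64 ug/mL. The step of an at least 1.0-fold lower number from compound 2 to compound 3 (0.00 log units; that floor lies within the scatter) and the step of an at least 1.1-fold higher number from compound 1 to compound 2 (0.04 log units; that floor lies within the scatter) also stay within the scatter. Compound 4 `COc1nc(-c2ccccc2Cl)ccc1[C@@H](c1ccccc1)[C@@](O)(CCN(C)C)c1cccc2ccccc12` differs from compound 3 by 2-chlorophenyl in place of 3-fluorophenyl on an aromatic carbon. Because a 1.1-fold higher number from compound 1 to compound 3 (0.04 log units; within the scatter) and an at least 1.0-fold lower number from compound 2 to compound 3 (0.00 log units; that floor lies within the scatter) stayed within the scatter, no shift beyond the scatter is expected, and the estimated step is a 1.0-fold lower number from compound 3 to compound 4 (0.02 log units; within the scatter). Compound 4 is therefore estimated at 60 ug/mL, ranging from 40 ug/mL to 80 ug/mL.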

Compound 4, half-maximal cytotoxic concentration: > 64 ug/mL
Compound 4: no number, only a limit; the forecaster's own chance of this, stated with the estimate: 35%; middle value at least 1.0-fold (0.02 log units) away from the limit.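

In this assay compound 4 gives only a limit, > 64 ug/mL, so 2-chlorophenyl at this position next to the ring nitrogen adds no readable number. The steps of an at least 1.0-fold higher number from compound 3 to compound 4 (0.00 log units; that floor lies within the scatter) and an at least 1.1-fold higher number from compound 1 to compound 4 (0.04 log units; that floor lies within the scatter) have floors within the scatter, and the step between compound 2 and compound 4 cannot be read, so this exchange shows no change beyond the scatter. The top of the readable range is reached a second time: the limit of > 64 ug/mL in this assay, at which 2 of the 4 values shown sit.

Going by these compounds, how far compound 2 and compound 4 lie past that limit remains open. Also open, on these data alone, is whether an amine or a carboxylic acid on this phenyl ring would move the number beyond the scatter.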